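What if compound 2 loses its carboxymethyl?

This account rests on a few compounds, and the source may have more. Where it says the series, first, only, none or still open, it means among the compounds named here.

In a physicochemical assay for solubility, in phosphate buffer, measured as kinetic solubility, with a stated time of 1 h, at pH 7.4 (a lower number here means a less soluble compound, a higher number a more soluble compound), compound 2 `O=C(O)Cc1ccccc1-c1cccc(NC(=O)OCc2ccccc2)c1` gives 287 ug/mL and compound 1 `O=C(O)Cc1cccc(-c2cccc(NC(=O)OCc3ccccc3)c2)c1` gives 221 ug/mL, two numbers that lie within the usual scatter of each other. Both compounds carry carboxymethyl, at different places on a shared core. Compound 3 `O=C1CN(Cc2ccc(-c3ccccc3)cc2)C(=O)N1c1ccccc1` has a different core and gives 7.5 ug/mL, so compound 2 stands well above it, beyond the scatter. Compound 2 therefore sits at the upper end of this small set, level with compound 1.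

The next compound to consider is compound 4 `O=C(Nc1cccc(-c2ccccc2)c1)OCc1ccccc1`, which differs from compound 2 by one change hydrogen in place of carboxymethyl on an aromatic carbon, ortho to a large group. For the measured compounds named here, no measured pair here shows this change on its own, so any forecast is a judgement rather than a reading from the data. Going by the values given here, the only measured compound without carboxymethyl is compound 3 at 7.5 ug/mL, and its different core makes it a rough guide only. A large downward step a 48-fold lower number from compound 2 to compound 4 (1.68 log units; beyond the scatter) is expected in this assay, well beyond the scatter. The estimate for compound 4 is 6 ug/mL with an expected range from 1.5 ug/mL to 25 ug/mL in this measurement.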

Compound 4, solubility: 5 ug/mL
Estimate against measurement, compound 4: 1.2-fold (0.08 log units) above, within the range that was stated.
By their numbers in this assay, from the lowest: compounds 4 and 3 (each within the scatter of the next); then compounds 1 and 2 (each within the scatter of the next).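

For the compounds shown here, the first matched comparison here isolates carboxymethyl: in this assay, putting hydrogen in its place on an aromatic carbon, ortho to a large group, gives a 57-fold lower number from compound 2 to compound 4 (1.76 log units; beyond the scatter), a large step beyond the scatter. The same exchange at the other place on the shared core gives a 44-fold lower number from compound 1 to compound 4 (1.65 log units; beyond the scatter), again large and beyond the scatter. Compounds 1 and 2 had already shown that moving carboxymethyl on this core leaves the numbers within the scatter of each other, while these steps add that having carboxymethyl somewhere on the core, rather than hydrogen, goes with a far higher number in all three compounds that share it.

No measurement among these results accounts for the size of either step, so only the size is established here. Still open, going by these compounds, is whether another group at the same place, such as an amine, a hydroxyl or a longer chain ending in a carboxylic acid, would give numbers close to those of compound 2 or close to those of compound 4, and whether the same exchange would give a similar step on a different core.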